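Inverting a Ring Stereocentre: Half-Life in Buffer

The source may hold more compounds than are shown below. What is called first, only, known or untested is meant among the compounds shown, and "the series" means these compounds.

Measured so far:
compound 1, `CC(C)(C)C1=C(C(=O)O)N2C(=O)[C@H]([C@H](O)c3ccncc3)[C@H]2O1`, 6.4 h
compound 2, `CC(C)(C)C1=C(C(=O)O)N2C(=O)[C@H]([C@H](O)CCc3ccncc3)[C@H]2O1`, 13.7 h

In an ADME assay, in phosphate buffer, at 28 degrees C, at pH 7.0 (a lower number here means that the compound disappears faster, a higher number that the compound lasts longer), compound 1 gives 6.4 h. Going by the values given here, compound 2 gives 13.7 h in this assay, the higher of the two numbers; the only measured step, a 2.1-fold higher number from compound 1 to compound 2 (0.33 log units; beyond the scatter), separates them, so compound 2 stands at the top of this small set, with compound 1 as its nearest neighbour.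

Compound 3, `CC(C)(C)C1=C(C(=O)O)N2C(=O)[C@H]([C@H](O)CCc3ccncc3)[C@@H]2O1`, is not yet measured. It differs from compound 2 in this way: the two compounds have the same atoms and bonds and differ only in configuration as drawn: 1 of 3 stereo elements differ; a stereocentre at a saturated ring carbon is drawn R in compound 2 and S in compound 3. Among the compounds with values here, no measured step bears on this change: the one step on record, a 2.1-fold higher number from compound 1 to compound 2 (0.33 log units; beyond the scatter), concerns a chain extension at the carbon bearing the hydroxyl group, not the configuration of the ring. Going by these compounds, there is thus no basis in the data for a direction, and the size of any effect is unknown. The estimate for compound 3 is therefore anchored on compound 2 with a wide range, and the expected step from compound 2 to compound 3 is a 1.2-fold lower number from compound 2 to compound 3 (0.10 log units; within the scatter). Compound 3 is expected to give 11 h, between 3 h and 35 h.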

Compound 3, half-life: 7.1 h
Beside the measured number, compound 3's estimate is 1.5-fold (0.19 log units) above it; low and high end bracket the measured number.
By their numbers in this assay, from the lowest: compounds 1, 3 and 2 (each within the scatter of the next, the first and the last beyond it).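

In this assay the inversion of the stereocentre at the saturated ring carbon comes to a 1.9-fold lower number from compound 2 to compound 3 (0.29 log units; within the scatter). Going by these compounds alone, this is the first reading at this position, as compound 1 and compound 2 carry the same configuration there as drawn and so could say nothing about it. The step stays within the scatter, so in this one pair the inversion cannot be told apart from repeat variation, and no other change in the structures clouds the comparison: the fact that compounds 2 and 3 differ only in the configuration as drawn.

The compounds shown leave open whether the configuration at this ring carbon would read the same with the pyridin-4-yl group of compound 1 on the chain carbon, or with a longer chain than the 2-(pyridin-4-yl)ethyl of compound 2 and compound 3. They also leave open what a phenyl ring or an amine in place of the pyridin-4-yl group would do to the half-life in this assay, and whether inverting the carbon that bears the hydroxyl group, drawn the same in all three compounds, would matter more than inverting the ring carbon.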